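A few compounds are considered here, and "the series" means these few. Any claim that something is new, unique, unknown or untested is made for them only; others in the source may bear on it.

Of the compounds shown here, three that share one core have been measured in an assay on isolated protein for inhibition of Amine oxidase [flavin-containing] A (Homo sapiens), read by fluorescence and spectrophotometry, with a stated time of 20 min; on this read-out higher numbers stand for weaker inhibition and lower numbers for stronger inhibition. Compound 1 `O=C1/C(=C/c2cccc(F)c2)Cc2cc(O)ccc21` gives 458 nM in this assay. Compound 2 `Cc1cccc(/C=C2\Cc3cc(O)ccc3C2=O)c1` gives 860 nM in this assay. Compound 3 `O=C1/C(=C/c2cccc(O)c2)Cc2cc(O)ccc21` gives 1200 nM in this assay. Compound 3 stands highest of the three: the step of a 2.6-fold higher number from compound 1 to compound 3 (0.42 log units; beyond the scatter) lies beyond the scatter, whereas a 1.4-fold higher number from compound 2 to compound 3 (0.14 log units; within the scatter) and a 1.9-fold higher number from compound 1 to compound 2 (0.27 log units; within the scatter) lie within it, so compound 3 cannot be separated from compound 2 on these numbers.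

Compound 4 `COc1cccc(/C=C2\Cc3cc(O)ccc3C2=O)c1` has not yet been measured. It differs from compound 3 by methyl in place of hydrogen on an oxygen on an aromatic ring. Going by the values given here, none of the measured steps exchanges hydroxy for methoxy, so their bearing on this change is indirect. What they show is that the hydroxy-bearing compound 3 sits at the high end, separated from compound 1 by a 2.6-fold higher number from compound 1 to compound 3 (0.42 log units; beyond the scatter) and from compound 2 by a 1.4-fold higher number from compound 2 to compound 3 (0.14 log units; within the scatter), a spread that is modest overall. Because compound 1 stands at 458 nM and compound 2 at 860 nM, both groups without a hydroxy on that aromatic carbon give numbers no higher than compound 3, and a step of a 1.3-fold lower number from compound 3 to compound 4 (0.12 log units; within the scatter) in this assay is expected, small and within the scatter. Compound 4 is therefore estimated at 900 nM in this assay, with a range from 400 nM to 2000 nM.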

Compound 4, half-maximal inhibitory concentration: 1190 nM
Compound 4: the middle estimate sits 1.3-fold (0.12 log units) below what was measured; measured number inside the range.
By their numbers in this assay, from the lowest: compounds 1, 2, 4 and 3 (each within the scatter of the next, the first and the last beyond it).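

In this assay, going by these compounds alone, putting methyl on the oxygen of the hydroxy group makes no difference that can be read, a 1.0-fold lower number from compound 3 to compound 4 (0.00 log units; within the scatter), so at this position the free hydroxy and the methoxy cannot be told apart, a comparison that none of the earlier steps offered. Methoxy also behaves like hydroxy against the other two groups: a 2.6-fold higher number from compound 1 to compound 4 (0.41 log units; beyond the scatter) lies beyond the scatter, as does a 2.6-fold higher number from compound 1 to compound 3 (0.42 log units; beyond the scatter), whereas a 1.4-fold higher number from compound 2 to compound 4 (0.14 log units; within the scatter) lies within it, so the fluoro compound 1 is separated from both oxygen-bearing compounds, while the methyl compound 2 is separated from neither. The data offered here give no measured explanation for this result.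

The compounds shown leave open whether a longer chain on that oxygen, such as ethoxy, would still give a number that cannot be separated from those of compound 3 and compound 4. They also leave open whether an amine or a chloro group on that aromatic carbon would fall nearer to compound 1 or to the oxygen-bearing compounds.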